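The compounds below may be only part of what the source reports. "The series", "measured", "known", "first", "only" and "open" are said of these compounds alone.

Measured so far:
Compound 1, `Nc1nc(Cl)c(-c2ccccn2)c(N[C@@H]2C[C@H](CO)[C@@H](O)[C@H]2O)n1`: in an ADME assay on cells (Homo sapiens) for cytotoxicity, read by polymerase chain reaction, with a stated time of 3 days (on this read-out lower numbers stand for higher toxicity in this test and higher numbers for lower toxicity in this test), compound 1 reaches only a limit of the assay, > 25000 nM.
Compound 2, `Cc1nc(NCC2CCC2)nc(N[C@@H]2C[C@H](CO)[C@@H](O)[C@H]2O)c1-c1nc2ccccc2s1`: in this assay compound 2 also reaches only a limit of the assay, > 25000 nM.

Both values shown are limits rather than numbers, so compound 2 cannot be ranked against compound 1; the two share the same limit (the limit of > 25000 nM in this assay, at which 2 of the 2 values shown sit). Among the compounds with values here, no pair of measured compounds differs in just one place, so there is no measured step to lean on.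

Compound 3 is `Cc1nc(NCCCC(F)(F)F)nc(N[C@@H]2C[C@H](CO)[C@@H](O)[C@H]2O)c1-c1nc2ccccc2s1`. It differs from compound 2 in one place: 3,3,3-trifluoropropyl in place of cyclobutyl on a saturated chain carbon bound to a nitrogen on an aromatic ring. Because compound 2 already sits at the limit of > 25000 nM in this assay, at which 2 of the 2 values shown sit, and no measured change in this series points either way, the expected movement in this assay is a step that the limit leaves unreadable from compound 2 to compound 3, that is, nothing beyond the usual scatter of repeated measurements. Compound 3 is therefore expected to give about 30000 nM in this assay, within a range from 12000 nM to 80000 nM, and most likely the assay will again report only a limit rather than a number.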

Compound 3, half-maximal cytotoxic concentration: 3000 nM
Compound 3: the middle estimate sits 10-fold (1.00 log units) above what was measured; measured number below the stated range.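

In this assay, putting 3,3,3-trifluoropropyl in place of cyclobutyl on a saturated chain carbon bound to a nitrogen on an aromatic ring gives an at least 8.3-fold lower number from compound 2 to compound 3 (0.92 log units; beyond the scatter), and a lower number here stands for higher toxicity in this test, so this place on the molecule is not silent for cytotoxicity. Within the data shown here, compound 3 gives 3000 nM, the only true number among the values shown, which means that compounds with this shared core can register in this assay with a number. The real size of the step stays open-ended, because compound 2 gives only a limit and no number:  the limit of > 25000 nM in this assay, at which 2 of the 3 values shown sit.

The change removes a ring and brings in fluorine at the same time, so the compounds shown cannot say which of the two goes with the lower number, and a plain butyl chain without fluorine would help to separate them. They also leave open how this place would respond to a group of a different kind, such as an amine or a carboxylic acid at the end of the chain.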